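This account rests on a few compounds, and the source may have more. Where it says the series, first, only, none or still open, it means among the compounds named here.

Measured compounds:

Compound 1, `O=C1Nc2ccccc2/C1=N/N=C/c1ccco1`: 15800 nM
Compound 2, `Cc1ccc2c(c1)/C(=N/N=C/c1ccco1)C(=O)N2`: 8750 nM
Compound 3, `O=C1Nc2ccccc2/C1=N/N=C/c1ccc[nH]1`: 6250 nM

These values come from a functional assay on MCF7 cells (Homo sapiens) for cytotoxicity, read by sulforhodamine B assay, with a stated time of 48 h; a lower number here means a stronger inhibitor, a higher number a weaker inhibitor. Compound 2 differs from compound 1 by methyl in place of hydrogen on an aromatic carbon and this change gave a 1.8-fold lower number from compound 1 to compound 2 (0.26 log units; within the scatter). Compound 3 differs from compound 1 in its core by 1H-pyrrol-2-yl in place of furan-2-yl on a carbon with a double bond to nitrogen and this change gave a 2.5-fold lower number from compound 1 to compound 3 (0.40 log units; beyond the scatter). Compound 3 and compound 2 lie within the scatter of each other in this assay.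

Compound 4, `Cc1ccc2c(c1)/C(=N/N=C/c1ccc[nH]1)C(=O)N2`, has not yet been measured. It differs from compound 3 by methyl in place of hydrogen on an aromatic carbon and the place is the same as in the earlier pair, so this is the same change, now made on the core of compound 3. The earlier pair gave a 1.8-fold lower number from compound 1 to compound 2 (0.26 log units; within the scatter). The step expected here is a 1.6-fold lower number from compound 3 to compound 4 (0.19 log units; within the scatter). That expectation rests on compound 1 and compound 2, where the change gave a 1.8-fold lower number from compound 1 to compound 2 (0.26 log units; within the scatter), a step within the scatter, so no large shift is assumed. In this assay compound 4 is expected to give 4000 nM. The range expected for compound 4 runs from 1500 nM to 9000 nM.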

Compound 4, half-maximal inhibitory concentration: 9250 nM
Estimate against measurement, compound 4: 2.3-fold (0.36 log units) below, and the stated range ends below it.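

In this assay, methyl in place of hydrogen on an aromatic carbon gave a 1.5-fold higher number from compound 3 to compound 4 (0.17 log units; within the scatter), and although each methyl step alone lies within the scatter, the two steps do not agree: the same change on two cores in this assay, a 1.8-fold lower number (0.26 log units; within the scatter) from compound 1 to compound 2 and a 1.5-fold higher number (0.17 log units; within the scatter) from compound 3 to compound 4, 2.7-fold (0.43 log units) apart, beyond the scatter of two such steps

Putting 1H-pyrrol-2-yl in place of furan-2-yl gave a 1.1-fold higher number from compound 2 to compound 4 (0.02 log units; within the scatter), so a step that was beyond the scatter on the core of compound 1 was not repeated on the core of compound 2: the same change on two cores in this assay, a 2.5-fold lower number (0.40 log units; beyond the scatter) from compound 1 to compound 3 and a 1.1-fold higher number (0.02 log units; within the scatter) from compound 2 to compound 4, 2.7-fold (0.43 log units) apart, beyond the scatter of two such steps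

Neither step can therefore be assumed to keep its size from one core to another here, but this rests on just four compounds and does not show why the steps differ or what would happen on any other core.

The compounds shown leave open whether a chlorine, a methoxy group or a longer chain in the methyl's place would behave in the same way. Going by these compounds, it also remains open whether a thiophen-2-yl ring in place of furan-2-yl would depend on the core as 1H-pyrrol-2-yl does.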